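Carboxy in Place of Propyl at the Sulfur-Bound Carbon

A few compounds are considered here, and "the series" means these few. Any claim that something is new, unique, unknown or untested is made for them only; others in the source may bear on it.

Compound 2 `CCCCSc1nc(SCc2ccccc2)nc(=O)[nH]1` gives -1.81% in an assay for inhibition of Pro-cathepsin H (Homo sapiens), read by fluorescence, tested at 50 uM; a higher number here means more inhibition at the concentration tested (going by the name of the read-out), a lower number less inhibition. Of the two numbers shown, that of compound 2 is the lower, although the step from compound 1 `O=c1nc(SCc2ccccc2)nc(SCc2ccc(Cl)cc2)[nH]1`, which in this assay gives 6.91%, is a number 8.7 percentage points lower from compound 1 to compound 2 (within the scatter) and so within the scatter. Compound 3 `O=C(O)CSc1nc(SCc2ccccc2)nc(=O)[nH]1` differs from compound 2 by carboxy in place of propyl on a saturated chain carbon bound to a sulfur. Among the compounds with values here, only one measured step touches the same place, the saturated chain carbon bound to a sulfur: a number 8.7 percentage points lower from compound 1 to compound 2 (within the scatter), which stayed within the scatter. Because a number 8.7 percentage points lower from compound 1 to compound 2 (within the scatter) was small, no movement beyond the scatter is expected in this assay for the present change either, in neither direction. Compound 3 is therefore expected to give 2%, within a range from -10% to 14%. The step of a number 3.8 percentage points higher from compound 2 to compound 3 (within the scatter) is estimated to stay within the scatter.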

Compound 3, a percentage reported as inhibition, at one concentration (the size of the read-out at that concentration, not a potency): 6.89%
Beside the measured number, compound 3's estimate is 4.9 percentage points below it, within the range that was stated.
By their numbers in this assay, from the lowest: compounds 2, 3 and 1 (each within the scatter of the next).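

At the saturated chain carbon bound to a sulfur, carboxy now joins propyl and 4-chlorophenyl as a third kind of group, and it carries a hydrogen-bond donor and a hydrogen-bond acceptor that propyl lacks. In this assay carboxy in place of propyl gives a number 8.7 percentage points higher from compound 2 to compound 3 (within the scatter), and carboxy in place of 4-chlorophenyl gives a number 0 percentage points lower from compound 1 to compound 3 (within the scatter). Across these three groups, then, no step at this place leaves the scatter, even with a swap as different in its atoms as propyl to carboxy. No measurement is available that would account for this result. From the compounds shown here alone, whether an amine, a hydroxy group or a longer chain at this place would give a step beyond the scatter remains open, and so does whether a change elsewhere on the shared core would.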